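A few compounds are considered here, and "the series" means these few. Any claim that something is new, unique, unknown or untested is made for them only; others in the source may bear on it.

Measured compounds:
compound 1, `COc1cc(NC(C)CCCNC(=O)NNC(=O)Nc2cccc(F)c2)c2ncccc2c1`: 108000 nM
compound 2, `COc1cc(NC(C)CCCNC(=O)Nc2ccc(C(F)(F)F)cc2)c2ncccc2c1`: 7400 nM

In a functional assay on L1210 cells (Mus musculus) for inhibition, read by MTT assay, with a stated time of 72 h (a lower number here means a stronger inhibitor, a higher number a weaker inhibitor), compound 1 gives 108000 nM, the highest of the two numbers at hand. Its nearest neighbour is compound 2, which in this assay gives 7400 nM. Within the data shown here, the only measured step is a 15-fold lower number from compound 1 to compound 2 (1.16 log units; beyond the scatter), where 4-(trifluoromethyl)phenyl stands in place of ((3-fluorophenyl)carbamoyl)amino on an amide-type nitrogen; it removes the whole carbamoylamino arm rather than altering the aryl group on it.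

Compound 3, `COc1cc(NC(C)CCCNC(=O)NNC(=O)Nc2ccc(O)cc2)c2ncccc2c1`, is not yet measured. Relative to compound 1 the change is 4-hydroxyphenyl in place of 3-fluorophenyl on an amide-type nitrogen. Among the measured compounds shown here, no measured step exchanges one aryl for another on the amide-type nitrogen, so the step from compound 1 to compound 2 does not bear on this change, and the series gives no direction for it. The expectation is therefore no step beyond the scatter, with wide uncertainty: the estimated step is a 1.1-fold lower number from compound 1 to compound 3 (0.03 log units; within the scatter). Compound 3 is expected to give about 100000 nM in this assay, within 30000 nM to 300000 nM.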

Compound 3, half-maximal inhibitory concentration: 95000 nM
For compound 3 the middle estimate is 1.1-fold (0.02 log units) above the measured one; low and high end bracket the measured number.
By their numbers in this assay, from the lowest: compound 2; then compounds 3 and 1 (each within the scatter of the next).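

In this assay, the exchange of one aryl group for another on the amide-type nitrogen gives a 1.1-fold lower number from compound 1 to compound 3 (0.06 log units; within the scatter), so 3-fluorophenyl and 4-hydroxyphenyl are not told apart at this position, even though 4-hydroxyphenyl brings a hydrogen-bond donor and acceptor that 3-fluorophenyl lacks. The large gap to the compound without the carbamoylamino arm also persists with the new aryl group, as a 13-fold higher number from compound 2 to compound 3 (1.11 log units; beyond the scatter) shows alongside a 15-fold lower number from compound 1 to compound 2 (1.16 log units; beyond the scatter), and so it is seen with either of these two aryl groups on the arm. No evidence at hand accounts for the flat aryl exchange or for that gap.

Still open, as far as these compounds go, is whether the gap to compound 2 belongs to the carbamoylamino arm or to the 4-(trifluoromethyl)phenyl group, and 4-(trifluoromethyl)phenyl carried on the arm would separate the two. Also open, from the compounds shown here alone, is how this position would read with an amine or a carboxylic acid on the aryl ring, or with a longer chain in place of the arm.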